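A side-chain swap from compound 1 to compound 4

The source may hold more compounds than are shown below. What is called first, only, known or untested is meant among the compounds shown, and "the series" means these compounds.

In an ADME assay on J774 cells (Mus musculus) for cytotoxicity, read by MTT assay, with a stated time of 48 h (a higher number here means a weaker inhibitor, a lower number a stronger inhibitor), compound 1 (`CN(C)CC(=O)NCCNc1cc(/C=C/c2ccccc2)nc2ccccc12`) gives 15000 nM as its reading. Compound 2 (`O=C(CN1CCCC1)NCCNc1cc(/C=C/c2ccccc2)nc2ccccc12`) gives 12500 nM and sits within the scatter of compound 1. Compound 3 (`O=C(CNc1ccccc1)NCCCCNc1cc(/C=C/c2ccccc2)nc2ccccc12`) gives 3300 nM and lies clearly lower. Compound 4 (`CCOCC(=O)NCCCCNc1cc(/C=C/c2ccccc2)nc2ccccc12`) is still unmeasured and differs from compound 1 on a saturated chain carbon (2-(((ethoxymethyl)carbonyl)amino)ethyl in place of (((dimethylamino)methyl)carbonyl)amino on a saturated chain carbon, two bonds along the chain from a nitrogen on an aromatic ring). Going by the values given here, the one measured step (a 1.2-fold lower number from compound 1 to compound 2 (0.08 log units; within the scatter)) swaps a different group, so it says little about this change. Among the compounds with values here, compound 3 at 3300 nM is the only clearly lower reading, which gives a weak hint of a move downward. The expected step (a 2.5-fold lower number from compound 1 to compound 4 (0.40 log units; beyond the scatter)) in this assay is therefore modest and uncertain. Compound 4 is expected at 6000 nM (estimated range 2500 nM to 14000 nM).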

Compound 4, half-maximal inhibitory concentration: 7200 nM
For compound 4 the middle estimate is 1.2-fold (0.08 log units) below the measured one, and the stated range covers the measured number.
By their numbers in this assay, from the lowest: compound 3; then compounds 4, 2 and 1 (each within the scatter of the next, the first and the last beyond it).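

Measured by this assay, replacing the side chain gives a modest change in a 2.1-fold lower number from compound 1 to compound 4 (0.32 log units; beyond the scatter) but no separation in a 1.7-fold lower number from compound 2 to compound 4 (0.24 log units; within the scatter). With the four-carbon-linked chain of compound 3 retained, ethoxy in place of anilino gives a 2.2-fold higher number from compound 3 to compound 4 (0.34 log units; beyond the scatter), so the group on the saturated chain carbon bound to the carbonyl carbon alters this reading. No measurement here gives a cause for these steps. The compounds shown do not separate the effect of ethoxy from that of the 2-(((ethoxymethyl)carbonyl)amino)ethyl chain extension. Going by these compounds, how a carboxylic acid or a methoxy group at that carbon would read remains open.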